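A few compounds are considered here, and "the series" means these few. Any claim that something is new, unique, unknown or untested is made for them only; others in the source may bear on it.

This study looks at how a set of related compounds behave in an ADME assay on Vero cells (Chlorocebus sabaeus) for cytotoxicity, read by MTT assay, with a stated time of 72 h (on this read-out lower numbers stand for stronger inhibition and higher numbers for weaker inhibition), where the question is simply how much of each compound is needed to harm the cells over the stated period.

Among the compounds with values here, compound 1, with structure `CC(=O)N1N=C(c2ccc(-n3c(C)ccc3C)cc2)OC1c1ccccc1[N+](=O)[O-]`, is the one member with a number to its name: in this assay compound 1 gives 175000 nM. Two further compounds belong to the same series but carry no result. Compound 2, with structure `Cc1ccc(C)n1-c1ccc(C(=O)N/N=C/c2ccccc2Cl)cc1`, gives "not determined" (no result reported) in this assay. Compound 3, with structure `CC(C)=NNC(=O)c1ccc(-n2c(C)ccc2C)cc1`, likewise gives "not determined" (no result reported) in this assay. Within the data shown here, with only one measured value, compound 1 cannot be placed above or below any companion; it stands alone as the sole reference point.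

Compound 4, with structure `CC(=O)N1N=C(c2ccc(-n3c(C)ccc3C)cc2)OC1c1cccc([N+](=O)[O-])c1`, has not yet been tested. It differs from compound 1 by 3-nitrophenyl in place of 2-nitrophenyl on a saturated ring carbon of the shared core. Among the measured compounds shown here, no pair of measured compounds shows how such a change plays out in this assay, so the expected step is guided only by the small size of the rearrangement. The step of no change at the digits printed from compound 1 to compound 4 (within the scatter) is expected to stay within the usual scatter, with no clear direction. Compound 4 is therefore estimated at 175000 nM, within a range from 80000 nM to 380000 nM.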

Compound 4, half-maximal inhibitory concentration: 188000 nM
Estimate against measurement, compound 4: 1.1-fold (0.03 log units) below, within the range that was stated.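

Putting 3-nitrophenyl in place of 2-nitrophenyl on the saturated ring carbon gives, in this assay, a 1.1-fold higher number from compound 1 to compound 4 (0.03 log units; within the scatter) and so stays within the normal spread of repeat measurements. Within the data shown here, this is the only comparison available, and it shows that at this carbon, a rearrangement that keeps the same atoms and simply joins them differently does not separate the two compounds on this read-out. Nothing shown here accounts for this result.

The step covers only these two placements of the nitro group on the phenyl ring, so the compounds shown leave open whether an amine or a carboxylic acid in place of the nitro group would give a similar number, and what a longer chain in place of the acetyl group would do. Among these compounds, compound 2 and compound 3 carry no result, so no step to either of them can be read, and their different structures add nothing yet to this picture.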